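A few compounds are considered here, and "the series" means these few. Any claim that something is new, unique, unknown or untested is made for them only; others in the source may bear on it.

In a functional assay on CHO cells with adenosine receptor A1 (Homo sapiens) as the target, read by cAMP accumulation and immunoassay, with a stated time of 6 min, tested at 0.01 uM (on this read-out lower numbers stand for a stronger effect and higher numbers for a weaker effect at the one concentration tested), compound 1, `Nc1scc(CN2CCN(c3cc(Cl)cc(Cl)c3)CC2)c1C(=O)c1ccc(Cl)cc1`, gives -1%. Compound 2, `Nc1scc(CN2CCN(c3ccc(OC(F)(F)F)cc3)CC2)c1C(=O)c1ccc(Cl)cc1`, gives 0% in this assay, and compound 3, `Nc1scc(CN2CCN(c3ccc(F)cc3F)CC2)c1C(=O)c1ccc(Cl)cc1`, gives 0%. Compound 3 thus stands level with compound 2 at the digits shown, and the step of a number 1 percentage points higher from compound 1 to compound 3 (within the scatter) places it within the scatter of compound 1 as well. Compound 4 is `Nc1scc(CN2CCN(c3cccc(Cl)c3)CC2)c1C(=O)c1ccc(Cl)cc1`; the change from compound 3 is 3-chlorophenyl in place of 2,4-difluorophenyl on an amine nitrogen in a ring. All three measured steps concern a change of exactly this group on the same ring nitrogen: a number 1 percentage points higher from compound 1 to compound 2 (within the scatter), a number 1 percentage points higher from compound 1 to compound 3 (within the scatter) and no change at the digits printed from compound 2 to compound 3 (within the scatter). None of them moved the read-out beyond the scatter, so for compound 4 the expectation is a step of no change at the digits printed from compound 3 to compound 4 (within the scatter) in this assay, which is no change beyond the scatter. Compound 4 is therefore estimated to give 0% in this assay, with a range from -10% to 10%.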

Compound 4, a percentage reported as activity, at one concentration (the size of the read-out at that concentration, not a potency): -3.1%
The estimate for compound 4 lay 3.1 percentage points above the measured number, within the range that was stated.
By their numbers in this assay, from the lowest: compounds 4, 1, 2 and 3 (each within the scatter of the next).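

In this assay, the 3-chlorophenyl group on the ring nitrogen joins the other aryl groups without leaving the scatter, with a number 3.1 percentage points lower from compound 3 to compound 4 (within the scatter) and a number 3.1 percentage points lower from compound 2 to compound 4 (within the scatter). It also gives the first view of a single substituent change on this aryl group rather than an exchange of the whole group: a number 2.1 percentage points lower from compound 1 to compound 4 (within the scatter), so hydrogen in place of chloro on an aromatic carbon has no effect beyond the scatter here, and none of the four compounds goes against this flat picture at the one concentration tested. No available evidence explains this result.

On these data alone, it remains open whether an aryl group carrying an amine or a carboxylic acid, or a non-aromatic group such as cyclohexyl, on this nitrogen would move the read-out. The compounds shown also leave open what a change elsewhere on the shared core would do.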